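Replacing iodo with naphthalen-2-yl on a shared core

A few compounds are considered here, and "the series" means these few. Any claim that something is new, unique, unknown or untested is made for them only; others in the source may bear on it.

- compound 1 `C[C@@]1(O)[C@H](O)[C@@H](CO)O[C@H]1n1cc(I)c2c(N)ncnc21`: 19800 nM
- compound 2 `C[C@@]1(O)[C@H](O)[C@@H](CO)O[C@H]1n1cc(-c2ccccc2)c2c(N)ncnc21`: > 44000 nM
- compound 3 `C[C@@]1(O)[C@H](O)[C@@H](CO)O[C@H]1n1cc(-c2cccc3ccccc23)c2c(N)ncnc21`: > 44000 nM

For the measured compounds named here, in a toxicity assay on Huh-7 cells (Homo sapiens) for cytotoxicity, with a stated time of 3 days (on this read-out higher numbers stand for lower toxicity in this test and lower numbers for higher toxicity in this test), compound 1 gives 19800 nM, the only true number among the three and the lowest reading, so it is the most toxic here. Compound 2 gives > 44000 nM, which is a limit of the assay. Compound 3 gives > 44000 nM, also a limit.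

The unmeasured compound 4 `C[C@@]1(O)[C@H](O)[C@@H](CO)O[C@H]1n1cc(-c2ccc3ccccc3c2)c2c(N)ncnc21` has naphthalen-2-yl in place of iodo on an aromatic carbon. Going by the values given here, two measured steps bear on this change. Replacing iodo with phenyl gave an at least 2.2-fold higher number from compound 1 to compound 2 (0.34 log units; beyond the scatter). Replacing iodo with naphthalen-1-yl gave an at least 2.2-fold higher number from compound 1 to compound 3 (0.34 log units; beyond the scatter). Going by these compounds, both of these end at the limit of > 44000 nM in this assay, at which 2 of the 3 values shown sit, so their true size remains open. A similar rise towards lower toxicity is therefore expected in this assay, probably again reaching the limit. The expected change is a 2.2-fold higher number from compound 1 to compound 4 (0.35 log units; beyond the scatter). For compound 4 the estimated value is 44000 nM, with an expected range from 25000 nM to 80000 nM.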

Compound 4, half-maximal cytotoxic concentration: 20100 nM
The estimate for compound 4 lay 2.2-fold (0.34 log units) above the measured number; the whole stated range lies above it.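

In this assay, replacing iodo with a two-ring aromatic group at this carbon does not by itself move the reading, because the step is a 1.0-fold higher number from compound 1 to compound 4 (0.01 log units; within the scatter). How the naphthalene is attached does matter among these compounds: naphthalen-2-yl in place of naphthalen-1-yl gives an at least 2.1-fold lower number from compound 3 to compound 4 (0.34 log units; beyond the scatter), and naphthalen-2-yl in place of phenyl gives an at least 2.1-fold lower number from compound 2 to compound 4 (0.34 log units; beyond the scatter). Compound 2 and compound 3 both stand at a limit rather than a true number, so the full size of these two steps stays unknown: the limit of > 44000 nM in this assay, at which 2 of the 4 values shown sit.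

The compounds shown leave open how an amine or a longer carbon chain at this carbon would read in this assay. They also leave open whether a phenyl ring carrying a methoxy group would stay at the limit or fall towards compound 4.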